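This account rests on a few compounds, and the source may have more. Where it says the series, first, only, none or still open, it means among the compounds named here.

Compound 1 `CCOC(=O)c1c(-c2cccc(OC(C)C)c2)[nH]c2cc(OC)ccc2c1=O`: > 21500 nM
Compound 2 `CCOC(=O)c1c(-c2cccc(Cl)c2)[nH]c2cc(OC)ccc2c1=O`: > 21500 nM
Compound 3 `CCOC(=O)c1c(-c2cccc(Cl)c2)[nH]c2cc(OC)c(Cl)cc2c1=O`: not yet measured

These readings come from an ADME assay on BJ cells (Homo sapiens) for cytotoxicity, read by luminescence, with a stated time of 72 h; on this read-out lower numbers stand for an effect already at smaller amounts and higher numbers for an effect only at larger amounts of compound. Compound 2 gives > 21500 nM, which is a limit of the assay and not a number. Compound 1 gives > 21500 nM, which is also a limit. Taken together, the evidence so far is the limit of > 21500 nM in this assay, at which 2 of the 2 values shown sit.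

Compound 3 keeps the shared core of compound 2 and makes one change, chloro in place of hydrogen on an aromatic carbon. The new chloro sits ortho to a methoxy group.

Among the measured compounds shown here, only one measured step bears on this change. It is a step that the two limits leave unreadable from compound 1 to compound 2, with chloro in place of isopropoxy on an aromatic carbon. That step has no readable size, so it offers no measured effect to carry over. The expectation therefore rests on compound 2, with its limit of > 21500 nM, and compound 3 will most likely report a limit as well.

In this assay the expected result is a number no higher from compound 2 to compound 3 (the limit leaves the size open), with no change beyond the scatter foreseen. For compound 3 the estimate is 21500 nM, with an expected range from 11000 nM to 43000 nM.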

Compound 3, half-maximal effective concentration: > 21500 nM
Compound 3 gave a limit, no number; the forecaster's own chance of this, stated with the estimate: 80%; the middle value sits exactly at the limit.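

Compound 2 and compound 3 each give a limit of the assay rather than a number, so the step between them, the added chloro, cannot be read. The compounds shown leave open at what amount any of them would show an effect in this assay, and whether any change on the shared core would alter that; all that stands so far is this: the limit of > 21500 nM in this assay, at which 3 of the 3 values shown sit.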